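Aryl change on compound 1: expected cytotoxicity

The compounds below may be only part of what the source reports. "The series", "measured", "known", "first", "only" and "open" are said of these compounds alone.

Within the data shown here, in a functional assay on PC-3 cells (Homo sapiens) for cytotoxicity, read by MTT assay, with a stated time of 72 h (on this read-out higher numbers stand for weaker inhibition and lower numbers for stronger inhibition), compound 1 `COc1ccc(/C=N/NC(=O)Nc2cc3c(Nc4ccc(F)c(Cl)c4)ncnc3cc2O[C@H]2CCOC2)cc1` gives 34100 nM, the higher of the two numbers so far. Compound 2 `CC(C)(C)c1cc(/C=N/NC(=O)Nc2cc3c(Nc4ccc(F)c(Cl)c4)ncnc3cc2O[C@H]2CCOC2)cc(C(C)(C)C)c1O` gives 13100 nM, a lower number beyond the scatter. Compound 3 `CCN(CC)c1ccc(/C=N/NC(=O)Nc2cc3c(Nc4ccc(F)c(Cl)c4)ncnc3cc2O[C@H]2CCOC2)c(O)c1` carries 4-(diethylamino)-2-hydroxyphenyl in place of 4-methoxyphenyl on a carbon with a double bond to nitrogen. Among the measured compounds shown here, no measured pair isolates this change, so the only guide is the gap between the two values. A small expected move toward a lower number is a 2.3-fold lower number from compound 1 to compound 3 (0.36 log units; beyond the scatter). For compound 3 the estimate is 15000 nM, with an expected range of 5000 nM to 45000 nM.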

Compound 3, half-maximal inhibitory concentration: 4590 nM
For compound 3 the middle estimate is 3.3-fold (0.51 log units) above the measured one; measured number below the stated range.
By their numbers in this assay, from the lowest: compound 3; then compound 2; then compound 1.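

In this assay, among these compounds, 4-(diethylamino)-2-hydroxyphenyl in place of 4-methoxyphenyl on a carbon with a double bond to nitrogen gives a 7.4-fold lower number from compound 1 to compound 3 (0.87 log units; beyond the scatter), the first step that isolates a change at this position. The entering group adds a nitrogen and a hydrogen-bond donor together, so this single step cannot separate their contributions. Nothing measured here accounts for the step.

On these data alone, whether the step follows the diethylamino part, the hydroxy part or both stays open. Also open, as far as these compounds go, is how a phenyl carrying a dimethylamino group or a carboxylic acid would read.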